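The source may hold more compounds than are shown below. What is called first, only, known or untested is meant among the compounds shown, and "the series" means these compounds.

Compound 1 `CCc1ccccc1NC(=O)N[C@@H](C)c1ccccc1`, compound 2 `COc1ccccc1NC(=O)N[C@@H](C)c1ccccc1` and compound 3 `C[C@H](NC(=O)Nc1ccccc1F)c1ccccc1` share one core and differ from one another only in the group carried on a single aromatic carbon. In an ADME assay on the whole organism with Oryza sativa as the target, tested at 1 uM (on this read-out higher numbers stand for a weaker effect at the one concentration tested and lower numbers for a stronger effect), compound 1 gives 100%, compound 2 gives 99% and compound 3 gives 92%. The number for compound 3 is the smallest of the three shown, but the steps of a number 8 percentage points lower from compound 1 to compound 3 (within the scatter) and a number 7 percentage points lower from compound 2 to compound 3 (within the scatter), like the step of a number 1 percentage points lower from compound 1 to compound 2 (within the scatter), all sit within the scatter, so none of the three compounds is set apart from the others on this read-out.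

Compound 4 `C[C@H](NC(=O)Nc1cc(F)ccc1F)c1ccccc1` arises from compound 3 by one change: fluoro in place of hydrogen on an aromatic carbon. Among the measured compounds shown here, no measured step puts a fluoro group in place of a hydrogen. The two measured steps in which a fluoro group enters at all are a number 8 percentage points lower from compound 1 to compound 3 (within the scatter) and a number 7 percentage points lower from compound 2 to compound 3 (within the scatter), where it takes the place of ethyl or methoxy, and both stayed within the scatter. On that basis the added fluoro group is expected to produce no step beyond the scatter. Compound 4 is therefore expected to give about 93% in this assay, with a range from 80% to 100%. This estimate means an expected step of a number 1 percentage points higher from compound 3 to compound 4 (within the scatter), within the scatter.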

Compound 4, a percentage reported as activity, at one concentration (the size of the read-out at that concentration, not a potency): 98%
For compound 4 the middle estimate is 5 percentage points below the measured one; low and high end bracket the measured number.
By their numbers in this assay, from the lowest: compounds 3, 4, 2 and 1 (each within the scatter of the next).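

Among the compounds shown here, the new step, a number 6 percentage points higher from compound 3 to compound 4 (within the scatter), is the first in which a group is added to an aromatic carbon that carried only hydrogen, whereas the earlier steps exchanged one group for another on a single aromatic carbon. It shows that in this assay a fluoro group placed meta to a large group and para to a fluoro group does not set compound 4 apart from compound 3, so this position accepts this one added heavy atom without a step beyond the scatter. Nothing measured on these compounds bears on why the number behaves this way, and the result stands here without an explanation.

Fluoro is the only group shown on this carbon, so it remains open whether an amine, a carboxylic acid or a longer chain in the same place would produce a step beyond the scatter, and in which direction. With no step among these compounds lying beyond the scatter, it also remains open which change to the shared core, at this carbon or elsewhere, would clearly move the read-out at all.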